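The source may report more compounds than this note shows. Statements on the series, on what has been measured and on what is new or still open speak of the compounds shown alone.

Measured compounds:
compound 1, `CCCCOc1ccc(OCCCNC(C)C)cc1`, 56 nM
compound 2, `C=CCc1cc(OCCCC)ccc1OCCCNC(C)C`, 0.6 nM
compound 3, `C=CCc1cc(NC(C)=O)ccc1OCCCNC(C)C`, 65 nM

The three compounds were tested in an assay for inhibition of squalene synthase (Rattus norvegicus), using microsomes; on this read-out lower numbers stand for stronger inhibition and higher numbers for weaker inhibition. Compound 2 stands apart from the other two. The difference between compound 2 and compound 1 is hydrogen in place of allyl on an aromatic carbon, and this step is large: a 93-fold higher number from compound 2 to compound 1 (1.97 log units; beyond the scatter). The difference between compound 2 and compound 3 is acetamido in place of butoxy on an aromatic carbon, and the step is of similar size: a 110-fold higher number from compound 2 to compound 3 (2.03 log units; beyond the scatter). Compound 1 and compound 3 give values within the usual scatter of each other, so nothing separates them.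

Compound 4, `CC(=O)Nc1ccc(OCCCNC(C)C)cc1`, has not been measured. It differs from compound 3 in the following way: hydrogen in place of allyl on an aromatic carbon. This is the same kind of change as the one from compound 2 to compound 1, but not the same: in the earlier case the place was meta to a butoxy group, whereas here it is meta to an acetamido group, the two cores differing as described above. Among the measured compounds shown here, since the step from compound 2 to compound 1 was a 93-fold higher number from compound 2 to compound 1 (1.97 log units; beyond the scatter), a large loss is expected again, though with only one earlier example on a different core the size is uncertain. The estimated step is a 46-fold higher number from compound 3 to compound 4 (1.66 log units; beyond the scatter). Compound 4 is expected to give about 3000 nM in this assay, most likely between 600 nM and 15000 nM.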

Compound 4, half-maximal inhibitory concentration: > 2500 nM
Compound 4 gave a limit, no number; the forecaster's own chance of this, stated with the estimate: 10%; the middle value lies beyond the limit too.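

In this assay compound 4 gives > 2500 nM, which is a limit of the assay and not a number. Hydrogen in place of allyl brings a large loss on both cores, so the direction of this change carries over to the core of compound 3, with the new step being an at least 38-fold higher number from compound 3 to compound 4 (1.58 log units; beyond the scatter), but how far its size carries over cannot be read: the same change on two cores in this assay, a 93-fold higher number (1.97 log units; beyond the scatter) from compound 2 to compound 1 and an at least 38-fold higher number (1.58 log units; beyond the scatter) from compound 3 to compound 4; the limit leaves it open whether they differ. Acetamido in place of butoxy behaves the same way, with an at least 44-fold higher number from compound 1 to compound 4 (1.64 log units; beyond the scatter) as the new step, a large loss on the core without allyl as well as on the core with it, and here too the direction carries over while the size stays unsettled: the same change on two cores in this assay, a 110-fold higher number (2.03 log units; beyond the scatter) from compound 2 to compound 3 and an at least 44-fold higher number (1.64 log units; beyond the scatter) from compound 1 to compound 4; the limit leaves it open whether they differ.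

The compounds shown leave open whether the allyl group itself matters or whether a saturated propyl group in the same place would keep the low number of compound 2. They also leave open how a free amine in place of acetamido, or a longer chain in place of butoxy, would behave on either core.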